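The compounds below may be only part of what the source reports. "The series", "measured", "known", "first", "only" and "open" are said of these compounds alone.

Measured in an ADME assay on BHK-21 cells (Mesocricetus auratus) for cytotoxicity, read by MTT assay, with a stated time of 72 h; on this read-out higher numbers stand for lower toxicity in this test and lower numbers for higher toxicity in this test:

Compound 1 `Cc1cccc(C2CC(c3ccc(Oc4ccccc4)cc3)=NN2c2ccc(S(N)(=O)=O)cc2)c1`: 8000 nM
Compound 2 `NS(=O)(=O)c1ccc(N2N=C(c3ccc(Oc4ccccc4)cc3)CC2c2ccccc2Cl)cc1`: 8000 nM
Compound 3 `NS(=O)(=O)c1ccc(N2N=C(c3ccc(Oc4ccccc4)cc3)CC2c2ccc(F)cc2)cc1`: 8000 nM

Compound 1 stands level with compounds 2 and 3 in this assay. The three measured steps all concern the group on the saturated ring carbon: no change at the digits printed from compound 1 to compound 2 (within the scatter), no change at the digits printed from compound 1 to compound 3 (within the scatter) and no change at the digits printed from compound 2 to compound 3 (within the scatter), each within the scatter. Compound 4 `Cc1cccc(C2CC(c3ccccc3)=NN2c2ccc(S(N)(=O)=O)cc2)c1` differs from compound 1 elsewhere: hydrogen in place of phenoxy on an aromatic carbon. Within the data shown here, none of the measured steps touches this aromatic position, so no measured step bears directly on the change. What the set does show is that three different groups on the saturated ring carbon leave the read-out in this assay unchanged, and nothing in the data points to a shift in either direction for compound 4. The step from compound 1 to compound 4 is therefore expected to be no change at the digits printed from compound 1 to compound 4 (within the scatter), that is, none beyond the scatter. Among the measured compounds shown here, compound 4 is estimated at 8000 nM, with a range from 3000 nM to 20000 nM, the range widened because this position has no measured precedent here.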

Compound 4, half-maximal cytotoxic concentration: 25000 nM
Compound 4: middle estimate off by 3.1-fold (0.49 log units), on the low side, and the stated range ends below it.
By their numbers in this assay, from the lowest: compounds 1, 2 and 3 (each within the scatter of the next); then compound 4.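

Unlike the three groups on the saturated ring carbon, which left the read-out level, the aromatic position para to a large group does register in this assay, with a 3.1-fold higher number from compound 1 to compound 4 (0.49 log units; beyond the scatter) when hydrogen replaces phenoxy. Among these compounds, on this read-out, the compound without the phenoxy group therefore shows lower toxicity in this test, so this is the first position in the set where a change moves the number beyond the scatter. Nothing measured here accounts for the shift.

The compounds shown leave open whether the whole phenoxy group matters or only part of it, as a methoxy group or an amine on the same aromatic carbon could help to show. They also leave open whether the same step holds with 2-chlorophenyl or 4-fluorophenyl on the saturated ring carbon.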